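The compounds below may be only part of what the source reports. "The series", "measured", "known", "first", "only" and "open" are said of these compounds alone.

In a toxicity assay on HepG2 2.2.15 cells (Homo sapiens) for cytotoxicity, read by CellTiter-Glo (on this read-out lower numbers stand for higher toxicity in this test and higher numbers for lower toxicity in this test), three compounds sharing one core have been measured: compound 1 `O=C1CC(Oc2ncc(F)cn2)CN1c1cnn2c1CN(C(=O)Nc1cc(F)c(F)c(F)c1)C(C1CC1)C2` gives 96200 nM, compound 2 `O=C1CC(c2cnco2)CN1c1cnn2c1CN(C(=O)Nc1cc(F)c(F)c(F)c1)C(C1CC1)C2` gives 139000 nM, and compound 3 `O=C1c2ccccc2CN1c1cnn2c1CN(C(=O)Nc1cc(F)c(F)c(F)c1)C(C1CC1)C2` gives 38500 nM, the lowest of the three numbers. Compound 4 `O=C1CC(c2ccccn2)CN1c1cnn2c1CN(C(=O)Nc1cc(F)c(F)c(F)c1)C(C1CC1)C2` has not been measured yet. Relative to compound 3, its change is a group of 12 heavy atoms (9 carbon, 2 nitrogen, 1 oxygen; one five-membered non-aromatic ring with 1 hetero atom, one six-membered aromatic ring with 1 hetero atom) in place of a group of 10 heavy atoms (8 carbon, 1 nitrogen, 1 oxygen; one five-membered non-aromatic ring with 1 hetero atom, one six-membered aromatic ring of carbon only), on an aromatic carbon. The entering 2-oxo-4-(pyridin-2-yl)pyrrolidin-1-yl sits on an aromatic carbon of a five-membered aromatic ring with 2 nitrogen.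

Among the measured compounds shown here, two measured steps bear on this change. Exchanging the substituent on a saturated ring carbon gave a 1.4-fold higher number from compound 1 to compound 2 (0.16 log units; within the scatter), so that exchange did not move the number beyond the usual variation between repeats. Replacing the whole group gave a 3.6-fold lower number from compound 2 to compound 3 (0.56 log units; beyond the scatter), a modest step. Compound 4 carries an aromatic ring on a saturated ring carbon, as compound 2 does, so that second step should largely reverse. The six-membered aromatic ring with 1 hetero atom in that position has no measured precedent among these compounds, which keeps the expectation loose. The expected change is a 2.3-fold higher number from compound 3 to compound 4 (0.37 log units; beyond the scatter), a modest rise. For compound 4 the estimated value is 90000 nM, with an expected range from 40000 nM to 200000 nM.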

Compound 4, half-maximal cytotoxic concentration: 96200 nM
Estimate against measurement, compound 4: 1.1-fold (0.03 log units) below; low and high end bracket the measured number.
By their numbers in this assay, from the lowest: compound 3; then compounds 1, 4 and 2 (each within the scatter of the next).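

In this assay, putting 2-oxo-4-(pyridin-2-yl)pyrrolidin-1-yl on the aromatic carbon in place of the group of compound 3 is a modest step beyond the scatter (a 2.5-fold higher number from compound 3 to compound 4 (0.40 log units; beyond the scatter)), and it places a group with a six-membered aromatic ring with 1 hetero atom on the saturated ring carbon among the higher numbers of this small set. Exchanges on that saturated ring carbon stay within the scatter (a 1.4-fold lower number from compound 2 to compound 4 (0.16 log units; within the scatter); no change at the digits printed from compound 1 to compound 4 (within the scatter)), so this test does not tell pyridin-2-yl, 1,3-oxazol-5-yl and (5-fluoropyrimidin-2-yl)oxy apart, and compound 3 alone stands beyond the scatter from the other three. Nothing available explains why these groups behave this way.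

The compounds shown leave open whether an amine or a carboxylic acid on the saturated ring carbon would stay with compounds 1, 2 and 4 or move the number away from them. They also leave open whether a phenyl group on that carbon would stay with those three compounds or fall toward compound 3, which would show whether a six-membered aromatic ring of carbon only goes with the lower number.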